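A few compounds are considered here, and "the series" means these few. Any claim that something is new, unique, unknown or untested is made for them only; others in the source may bear on it.

Measured in a functional assay on HeLa cells (Homo sapiens) for cytotoxicity, in the presence of a further agent that is not named here; a higher number here means a weaker inhibitor, a lower number a stronger inhibitor:
- compound 1 `Clc1ccc(-c2cc(-c3ccsc3)nc(-c3ccco3)c2)o1`: > 50000 nM (a limit)
- compound 2 `Clc1ccc(-c2cc(-c3cccnc3)nc(-c3ccsc3)c2)o1`: > 50000 nM (a limit)
- compound 3 `Clc1cccc(-c2cc(-c3ccc(Cl)o3)cc(-c3cccs3)n2)c1`: 12800 nM

Among the measured compounds shown here, compound 3 gives 12800 nM, the only true number in this small set. The values of compound 1 and compound 2 are both limits, so they cannot be placed exactly against it.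

Compound 4 `Clc1cccc(-c2cc(-c3ccc(Cl)o3)cc(-c3ccsc3)n2)c1` has not yet been measured. It carries thiophen-3-yl in place of thiophen-2-yl on an aromatic carbon, next to the ring nitrogen: thiophen-3-yl in place of thiophen-2-yl on an aromatic carbon.

For the measured compounds named here, only one measured step bears even indirectly on this change, a step that the two limits leave unreadable from compound 1 to compound 2. Its size cannot be read, and it involves a different exchange. Compounds 1 and 2 also carry thiophen-3-yl and sit at the limit of > 50000 nM in this assay, at which 2 of the 3 values shown sit, but each differs from compound 3 in more than one place, so they say little here.

Going by the values given here, with no measured step to suggest otherwise, the expected step is a 1.2-fold higher number from compound 3 to compound 4 (0.07 log units; within the scatter) in this assay, and none beyond the scatter is expected. For compound 4 the estimated value is 15000 nM, with an expected range of 6000 nM to 40000 nM.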

Compound 4, half-maximal inhibitory concentration: 8710 nM
Beside the measured number, compound 4's estimate is 1.7-fold (0.24 log units) above it; measured number inside the range.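

In this assay, among the compounds shown here, the first direct reading of this exchange on the aromatic carbon next to the ring nitrogen is a 1.5-fold lower number from compound 3 to compound 4 (0.17 log units; within the scatter), so the two thiophene attachments cannot be told apart here. With thiophen-3-yl kept at this carbon, the other exchanges give an at least 5.7-fold lower number from compound 2 to compound 4 (0.75 log units; beyond the scatter) and an at least 5.7-fold lower number from compound 1 to compound 4 (0.75 log units; beyond the scatter), which points to 3-chlorophenyl, rather than the thiophene attachment, as the change that matters among these compounds. Both of these steps start from a limit of the assay, so their full size stays unknown: the limit of > 50000 nM in this assay, at which 2 of the 4 values shown sit.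

From the compounds shown here alone, it remains open whether a group other than thiophen-2-yl or thiophen-3-yl at this carbon, such as an amine or a carboxylic acid, would shift the number beyond the scatter. Going by these compounds, it is equally open how a longer chain in place of 3-chlorophenyl would read in this assay.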